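This account rests on a few compounds, and the source may have more. Where it says the series, first, only, none or still open, it means among the compounds named here.

Measured so far:
compound 1 `CC1(C)[C@H]2CC[C@]1(C)N(Cc1cn(-c3cccc(C#N)c3)nn1)C(=O)C2` — 40 nM
compound 2 `Cc1ccc(-n2cc(CN3C(=O)C[C@@H]4CC[C@@]3(C)C4(C)C)nn2)cc1` — 480 nM

In a functional assay on HepG2 cells (Homo sapiens) for inhibition, read by MTT assay, with a stated time of 24 h (on this read-out higher numbers stand for weaker inhibition and lower numbers for stronger inhibition), compound 1 gives 40 nM, the lowest of the two numbers seen; compound 2 gives 480 nM. For the measured compounds named here, the only measured step, a 12-fold higher number from compound 1 to compound 2 (1.08 log units; beyond the scatter), comes from 4-methylphenyl in place of 3-cyanophenyl on an aromatic nitrogen. Compound 3 `COc1cccc(-n2cc(CN3C(=O)C[C@@H]4CC[C@@]3(C)C4(C)C)nn2)c1` has not been measured. It differs from compound 1 in one place: methoxy in place of cyano on an aromatic carbon. The step from compound 1 to compound 2 bears on this only loosely, since that step changed both the group and the ring position, whereas here the group stays on an aromatic carbon meta to a large group and only cyano gives way to methoxy. Because a 12-fold higher number from compound 1 to compound 2 (1.08 log units; beyond the scatter) was large, some loss of inhibition is expected when the cyano of compound 1 is gone, though probably less than for compound 2. Compound 3 is therefore expected to give 200 nM, within a range of 60 nM to 700 nM. That estimate means a 5.0-fold higher number from compound 1 to compound 3 (0.70 log units; beyond the scatter).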

Compound 3, half-maximal inhibitory concentration: 70 nM
Estimate against measurement, compound 3: 2.9-fold (0.46 log units) above; the measured number falls inside the stated range.
By their numbers in this assay, from the lowest: compounds 1 and 3 (each within the scatter of the next); then compound 2.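

In this assay the change from cyano to methoxy on this aromatic carbon gives a 1.8-fold higher number from compound 1 to compound 3 (0.24 log units; within the scatter) and so makes no readable difference, which shows that a low number here does not depend on the cyano group alone. The other new step, a 6.9-fold lower number from compound 2 to compound 3 (0.84 log units; beyond the scatter) with 3-methoxyphenyl in place of 4-methylphenyl, shows that the large gap seen earlier for compound 2 is not explained simply by the missing cyano. No measurement at hand accounts for these results.

The compounds shown leave open whether the weaker result of compound 2 comes from the methyl group itself or from where that group sits on the ring. They also do not show how an amine or a carboxylic acid on this aromatic carbon would read in this assay.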